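The compounds below may be only part of what the source reports. "The series", "measured", "known", "first", "only" and "open" are said of these compounds alone.

Measured compounds:
Compound 1, `Cc1cc(C)cc(-c2nnc(COc3cnn(C(C)(C)C)c(=O)c3Cl)o2)c1`: > 300 ug/mL
Compound 2, `CC(C)(C)n1ncc(OCc2nnc(-c3cc(F)c(F)cc3F)o2)c(Cl)c1=O`: 75.7 ug/mL

In a functional assay on the whole organism for inhibition, with Mythimna separata as the target, with a stated time of 5 days (a lower number here means that less compound is needed, a higher number that more compound is needed for the effect), compound 1 gives > 300 ug/mL; this is a limit of the assay and not a number (the limit of > 300 ug/mL in this assay, at which 1 of the 2 values shown sits). Compound 2 gives 75.7 ug/mL in this assay, and that is the only number shown among the two compounds. Within the data shown here, the one measured step, an at least 3.9-fold lower number from compound 1 to compound 2 (0.59 log units; beyond the scatter), is an exchange of the aromatic group on the shared core, and it went downward by an at least modest amount.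

Compound 3, `CC(C)(C)n1ncc(OCc2nnc(-c3cccs3)o2)c(Cl)c1=O`, is not yet measured. It differs from compound 2 in one place: thiophen-2-yl in place of 2,4,5-trifluorophenyl on an aromatic carbon. The measured step bears on it only loosely, since it too exchanges the group at the same place of the shared core, but the group entering here is a five-membered ring with a sulfur rather than a further fluorinated phenyl. Among the measured compounds shown here, with only that step to lean on, the expected change from compound 2 to compound 3 is a 1.5-fold higher number from compound 2 to compound 3 (0.16 log units; within the scatter), which may or may not exceed the scatter. Compound 3 is therefore estimated to give 110 ug/mL in this assay, with a range from 30 ug/mL to 300 ug/mL.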

Compound 3, half-maximal effective concentration: > 300 ug/mL
Compound 3 gave a limit, no number (the forecaster's own chance of this, stated with the estimate: 30%); middle value at least 2.7-fold (0.43 log units) from the limit.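

In this assay, placing thiophen-2-yl on this aromatic carbon in place of 2,4,5-trifluorophenyl gives an at least 3.9-fold higher number from compound 2 to compound 3 (0.59 log units; beyond the scatter), so the number seen for compound 2 does not carry over to this five-membered ring with a sulfur. Compound 3 gives > 300 ug/mL, which is a limit of the assay and not a number. Of the three groups at this place, only 2,4,5-trifluorophenyl yields a number, and the step between the other two cannot be read: the limit of > 300 ug/mL in this assay, at which 2 of the 3 values shown sit.

The compounds shown leave open whether the difference lies with the phenyl ring itself or with its fluorine atoms, a question that an unsubstituted phenyl or a phenyl bearing a single fluorine would address. Also open, on these data alone, is what the tert-butyl group and the chlorine contribute, as both stay the same across all three compounds, and a smaller alkyl group such as methyl in place of tert-butyl would speak to the first of these.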